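A few compounds are considered here, and "the series" means these few. Any claim that something is new, unique, unknown or untested is made for them only; others in the source may bear on it.

In a functional assay on DU-145 cells (Homo sapiens) for inhibition, read by trypan blue exclusion, with a stated time of 72 h (on this read-out higher numbers stand for weaker inhibition and lower numbers for stronger inhibition), three compounds have been measured:

- compound 1 `Cn1c(=O)c(S(=O)(=O)c2ccc(F)cc2)cc2cnc(Nc3ccc4occc4c3)nc21`: 5000 nM
- compound 2 `Cn1c(=O)c(S(=O)(=O)c2ccc(F)cc2F)cc2cnc(Nc3ccc4occc4c3)nc21`: 15000 nM
- compound 3 `Cn1c(=O)c(S(=O)(=O)c2ccc(F)cc2F)cc2cnc(Nc3ccc4c(c3)CC(=O)N4)nc21`: 100000 nM

Compound 1 has the lowest number of the three and therefore shows the strongest inhibition. Compound 4 `Cn1c(=O)c(S(=O)(=O)c2ccc(F)cc2)cc2cnc(Nc3ccc4[nH]ccc4c3)nc21` has not yet been measured. It differs from compound 1 by a single change: 1H-indol-5-yl in place of 1-benzofuran-5-yl on a nitrogen on an aromatic ring.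

The fluoro step, a 3.0-fold higher number from compound 1 to compound 2 (0.48 log units; beyond the scatter), concerns a different part of the structure and says little about this change. Going by the values given here, only one measured step alters the group on the same nitrogen: a 6.7-fold higher number from compound 2 to compound 3 (0.82 log units; beyond the scatter). That step brings in a group with a five-membered non-aromatic ring, whereas the 1H-indol-5-yl group keeps a five-membered aromatic ring. It therefore offers only a weak guide, pointing towards a higher number. A small rise is expected, and no step beyond the scatter is anticipated. The estimate amounts to a 1.4-fold higher number from compound 1 to compound 4 (0.15 log units; within the scatter), an expected step within the scatter. Compound 4 is estimated at 7000 nM, with an expected range from 1800 nM to 28000 nM.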

Compound 4, half-maximal inhibitory concentration: 300 nM
Estimate against measurement, compound 4: 23-fold (1.37 log units) above; measured number below the stated range.
By their numbers in this assay, from the lowest: compound 4; then compound 1; then compound 2; then compound 3.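

In this assay, going by these compounds alone, replacing 1-benzofuran-5-yl with 1H-indol-5-yl on the nitrogen gives a 17-fold lower number from compound 1 to compound 4 (1.22 log units; beyond the scatter), the first measured change at this position that lowers the number. Within the data shown here, the only earlier step there, a 6.7-fold higher number from compound 2 to compound 3 (0.82 log units; beyond the scatter), went the other way, so this position can move the number in either direction. The two groups match in heavy-atom count and ring types, yet the swap of the oxygen for a nitrogen, with one hydrogen-bond donor entering and one hydrogen-bond acceptor leaving, goes with a large step, and no measurement shown here explains it. Going by these compounds, it remains open whether the 1H-indol-5-yl group gives a similar step alongside the additional fluoro of compound 2. On these data alone, it is also open whether the step depends on the hydrogen on the indole nitrogen, which a methyl group in its place would test.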